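A few compounds are considered here, and "the series" means these few. Any claim that something is new, unique, unknown or untested is made for them only; others in the source may bear on it.

Working notes on the series. Compound 1, `CCOC(=O)C1=Cc2ccccc2OC1(OCc1cn(-c2ccc(C)cc2)nn1)C(F)(F)F`, gives 19700 nM in a functional assay on A549 cells (Homo sapiens) for inhibition, read by MTT assay, with a stated time of 24 h; on this read-out lower numbers stand for stronger inhibition and higher numbers for weaker inhibition. For compound 2, `CCOC(=O)C1=Cc2ccccc2OC1(OCc1cn(-c2ccccc2)nn1)C(F)(F)F`, this assay returns only a limit, > 150000 nM. Compound 3, `CCOC(=O)C1=Cc2ccccc2OC1(OCc1cn(-c2ccc(F)c([N+](=O)[O-])c2)nn1)C(F)(F)F`, gives 11900 nM in this assay. Compound 3 therefore holds the lowest of the two numbers shown, with compound 1 nearest to it; the remaining value is a limit rather than a number.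

The measured steps all change the group on the aromatic nitrogen. The step of an at least 7.6-fold higher number from compound 1 to compound 2 (0.88 log units; beyond the scatter) and the step of an at least 12-fold lower number from compound 2 to compound 3 (1.10 log units; beyond the scatter) show that this position can move the number by a large amount, while the step of a 1.7-fold lower number from compound 1 to compound 3 (0.22 log units; within the scatter) shows that two different aryl groups can also sit close together.

The next compound, compound 4, `CCOC(=O)C1=Cc2ccccc2OC1(OCc1cn(CC(=O)Nc2ccc(OC)cc2)nn1)C(F)(F)F`, follows the same line but exchanges the aryl group for a chain: ((4-methoxyphenyl)carbamoyl)methyl in place of 4-fluoro-3-nitrophenyl on an aromatic nitrogen. For the measured compounds named here, none of the measured steps places a non-aryl group on this nitrogen, so the expectation rests on the size of the changes seen rather than on a direct match. The step of a 2.1-fold higher number from compound 3 to compound 4 (0.32 log units; beyond the scatter) is expected to be modest, toward a higher number, with wide uncertainty. Compound 4 is estimated to give about 25000 nM, with a range from 6000 nM to 110000 nM.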

Compound 4, half-maximal inhibitory concentration: 29400 nM
The estimate for compound 4 lay 1.2-fold (0.07 log units) below the measured number, within the range that was stated.
By their numbers in this assay, from the lowest: compounds 3, 1 and 4 (each within the scatter of the next, the first and the last beyond it). At a limit, above all of these: compound 2.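

Compound 4 is the first compound shown with a chain rather than a directly attached aryl group on the aromatic nitrogen, and the ((4-methoxyphenyl)carbamoyl)methyl group, with its amide hydrogen, still gives a measurable number in this assay. The position therefore accepts more than directly attached aryl groups: the step of a 1.5-fold higher number from compound 1 to compound 4 (0.17 log units; within the scatter) stays within the scatter, although the step of a 2.5-fold higher number from compound 3 to compound 4 (0.39 log units; beyond the scatter) is a modest one beyond it, so the chain matches compound 1 but not compound 3. Compounds 1, 3 and 4 all carry a substituted aromatic ring and give numbers, compound 2 with plain phenyl stands apart, and the step of an at least 5.1-fold lower number from compound 2 to compound 4 (0.70 log units; beyond the scatter) is read against a limit of the assay rather than a number: the limit of > 150000 nM in this assay, at which 1 of the 4 values shown sits.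

The compounds shown do not separate the part played by the amide link from that of the 4-methoxyphenyl ring at its end, since a single chain stands here and neither a plain phenylcarbamoylmethyl group nor a simple butyl chain appears on this nitrogen. On these data alone, how a carboxylic acid or an amine at the end of a longer chain would read at this position also remains open.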